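This account rests on a few compounds, and the source may have more. Where it says the series, first, only, none or still open, it means among the compounds named here.

Measured compounds:
Compound 1 `COc1ccccc1C(=O)Nc1ccc(N2CCC(Oc3ccccc3)CC2)cc1C(=O)O`: in a toxicity assay on L3.6pl cells (Homo sapiens) for inhibition, read by ATP content, with a stated time of 72 h (a higher number here means a weaker inhibitor, a lower number a stronger inhibitor), compound 1 gives 38600 nM.
Compound 2 `COc1ccccc1C(=O)Nc1ccc(N2CCN(Cc3ccccc3)CC2)cc1C(=O)O`: in this assay compound 2 reaches only a limit, > 10000 nM.
Compound 3 `COc1ccc(C(=O)Nc2ccc(N3CCN(c4cc(Cl)ccc4C)CC3)cc2C(=O)O)cc1`: in this assay compound 3 gives 16800 nM.

Compound 2 stands at the weak end of what the numbers show, with no number of its own, only (the limit of > 10000 nM in this assay, at which 1 of the 3 values shown sits). For the measured compounds named here, no pair among the measured compounds differs in one place, so no measured step is available. Compound 4 `COc1ccccc1C(=O)Nc1ccc(N2CCN(CCCc3ccccc3)CC2)cc1C(=O)O` differs from compound 2 by phenethyl in place of phenyl on a saturated chain carbon bound to an amine nitrogen in a ring. With both numbered neighbours weak and compound 2 at a limit, the step that the limit leaves unreadable from compound 2 to compound 4 is expected to be none beyond the scatter. Compound 4 is estimated at 20000 nM, within 7000 nM to 60000 nM, in this assay.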

Compound 4, half-maximal inhibitory concentration: > 10000 nM
Compound 4 ended at the assay's limit; the forecaster's own chance of this, stated with the estimate: 40%; the middle value does not contradict the limit.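

Compound 2 and compound 4 both stand only at a limit in this assay, and the step between them cannot be read. On these data alone, whether phenethyl in place of phenyl changes inhibition at all remains open.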